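The source may hold more compounds than are shown below. What is called first, only, known or untested is meant among the compounds shown, and "the series" means these compounds.

Measured so far:
compound 1 `Cn1nc(N)c2c(=O)[nH]c(-c3ccccc3)cc21` — 8%
compound 2 `CC(=O)Nc1nn(C)c2cc(-c3ccccc3)[nH]c(=O)c12` — -9%

Both were tested in an assay on isolated protein for inhibition of RAC-alpha serine/threonine-protein kinase (Homo sapiens), read by mobility shift assay, tested at 30 uM (a lower number here means less inhibition, a higher number more inhibition at the concentration tested (going by the name of the read-out)), and compound 2 gives the lower of the two numbers. Among the compounds with values here, the one step seen so far, a number 17 percentage points lower from compound 1 to compound 2 (beyond the scatter), went with acetyl in place of hydrogen on a nitrogen on an aromatic ring. Compound 3 `CC(=O)Nc1nn(C)c2cc(-c3ccc(N4CCN(C)CC4)cc3)[nH]c(=O)c12` has not yet been measured. It differs from compound 2 in a single place: 4-methylpiperazin-1-yl in place of hydrogen on an aromatic carbon. Within the data shown here, no measured step bears on a change of this kind, since a number 17 percentage points lower from compound 1 to compound 2 (beyond the scatter) concerns a different group at a different place and so offers little guidance here. With nothing of the same kind to lean on, the expectation for compound 3 is a step of a number 7 percentage points higher from compound 2 to compound 3 (within the scatter), which is estimated to stay within the usual scatter. Compound 3 is therefore expected to give about -2% in this assay, with the estimate ranging from -18% to 18%.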

Compound 3, a percentage reported as inhibition, at one concentration (the size of the read-out at that concentration, not a potency): 4%
Compound 3: middle estimate off by 6 percentage points, on the low side, within the range that was stated.
By their numbers in this assay, from the lowest: compound 2; then compounds 3 and 1 (each within the scatter of the next).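

Placing 4-methylpiperazin-1-yl on an aromatic carbon of the six-membered aromatic ring of carbon only, para to a large group, goes with a number 13 percentage points higher from compound 2 to compound 3 (beyond the scatter) in this assay. Within the data shown here, this is the first look at this part of the molecule, since the earlier step concerned a nitrogen substituent elsewhere, and it shows that this position accepts a much larger group without the number falling, though the rise is modest and compound 3 still gives only 4%. No measurement here explains why the number moves with this change.

As far as these compounds go, whether morpholine or a carboxylic acid at the same place would go the same way remains open. So does whether 4-methylpiperazin-1-yl would give a similar step on compound 1, which lacks the acetyl group.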